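Swapping an Aryl Substituent on the Triazole Ring

The compounds below may be only part of what the source reports. "The series", "measured", "known", "first", "only" and "open" are said of these compounds alone.

Compound 2 `COc1ccc(/C=C\C(=O)O)c(OCc2cn(-c3ccccc3F)nn2)c1CC=C(C)C` gives the lowest of three numbers in a functional assay on A-431 cells (Homo sapiens) for cytotoxicity, read by MTT assay, with a stated time of 24 h (on this read-out lower numbers stand for stronger inhibition and higher numbers for weaker inhibition), with 12400 nM. Compound 1 `COc1ccc(/C=C\C(=O)O)c(OCc2cn(-c3ccc(NC(C)=O)cc3)nn2)c1CC=C(C)C` gives 23400 nM and compound 3 `COc1ccc(/C=C\C(=O)O)c(OCc2cn(-c3cccc(C#N)c3)nn2)c1CC=C(C)C` gives 22900 nM. The shared core is kept throughout, and only the aryl group on the triazole nitrogen varies. Compound 4 `COc1ccc(/C=C\C(=O)O)c(OCc2cn(-c3ccccc3C(=O)N3CCC(O)C3)nn2)c1CC=C(C)C` changes this aryl group again: (3-hydroxypyrrolidin-1-yl)carbonyl in place of fluoro on an aromatic carbon. The measured steps bearing on such a swap are a 1.9-fold lower number from compound 1 to compound 2 (0.28 log units; within the scatter), a 1.0-fold lower number from compound 1 to compound 3 (0.01 log units; within the scatter) and a 1.8-fold higher number from compound 2 to compound 3 (0.27 log units; within the scatter), all within the scatter, so this position has so far tolerated different aryl groups without a clear shift. A step of a 1.5-fold higher number from compound 2 to compound 4 (0.16 log units; within the scatter) is therefore expected, no larger than the scatter, and compound 4 is estimated at 18000 nM, likely between 8000 nM and 45000 nM.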

Compound 4, half-maximal inhibitory concentration: 31500 nM
The estimate for compound 4 lay 1.8-fold (0.24 log units) below the measured number; measured number inside the range.
By their numbers in this assay, from the lowest: compounds 2, 3, 1 and 4 (each within the scatter of the next, the first and the last beyond it).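

In this assay, among these compounds, the change gives a 2.5-fold higher number from compound 2 to compound 4 (0.40 log units; beyond the scatter), the first step at this position to go beyond the scatter, though only modestly. The aryl group here is therefore not entirely free to vary: replacing fluoro with (3-hydroxypyrrolidin-1-yl)carbonyl, which adds a ring and a hydrogen-bond donor, comes with a higher number. Nothing measured here accounts for this step. From the compounds shown here alone, it remains open which part of the new group matters: the carbonyl, the ring or the hydroxyl. A carboxylic acid or an open-chain amide on the same aromatic carbon could help separate these parts.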